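Changing the Carbamate Ester on a Kinase Inhibitor Core

A few compounds are considered here, and "the series" means these few. Any claim that something is new, unique, unknown or untested is made for them only; others in the source may bear on it.

Compound 1 `C[C@@H]1CN(C(=O)c2nc(Nc3cc(C4CC4)[nH]n3)c3cc(Cl)ccc3n2)CCN1C(=O)OC(C)(C)C`: 0.1%
Compound 2 `CC(OC(=O)N1CCN(C(=O)c2nc(Nc3cc(C4CC4)[nH]n3)c3cc(Cl)ccc3n2)C[C@H]1C)OC(=O)C(C)(C)C`: -6.9%
Compound 3 `COC(=O)N1CCN(C(=O)c2nc(Nc3cc(C4CC4)[nH]n3)c3cc(Cl)ccc3n2)C[C@H]1C`: 73.9%

In an assay for inhibition of serine/threonine-protein kinase PAK 4 (Homo sapiens), read by FRET and Z'-LYTE, with a stated time of 60 min, tested at 0.5 uM, in the presence of a further agent that is not named here (a lower number here means a weaker effect, a higher number a stronger effect of the compound at the concentration tested), compound 3 stands highest of the three, and both measured steps lead up to it: a number 73.8 percentage points higher from compound 1 to compound 3 (beyond the scatter) and a number 80.8 percentage points higher from compound 2 to compound 3 (beyond the scatter). Each step arrives at methyl from another ester group, and each is large. Compound 4 `C[C@@H]1CN(C(=O)c2nc(Nc3cc(C4CC4)[nH]n3)c3cc(Cl)ccc3n2)CCN1C(=O)OCC(Cl)(Cl)Cl` differs from compound 3 by trichloromethyl in place of hydrogen on a saturated chain carbon bound to an oxygen next to a carbonyl group. This change again replaces methyl on that oxygen with a longer group, so the two measured steps, read backwards, bear directly on it. A fall beyond the scatter is therefore expected for compound 4, though perhaps not as deep as those two steps: a number 43.9 percentage points lower from compound 3 to compound 4 (beyond the scatter). Compound 4 is estimated at 30%, with a range from 5% to 65%.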

Compound 4, a percentage reported as inhibition, at one concentration (the size of the read-out at that concentration, not a potency): -1.5%
Beside the measured number, compound 4's estimate is 31.5 percentage points above it; measured number outside the range, below it.
By their numbers in this assay, from the lowest: compounds 2, 4 and 1 (each within the scatter of the next); then compound 3.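

Trichloromethyl on the saturated chain carbon of the methyl ester gives a number 75.4 percentage points lower from compound 3 to compound 4 (beyond the scatter), so the loss at this oxygen is not tied to tert-butyl or to the pivaloyloxy-bearing group of compound 2. The 2,2,2-trichloroethyl group instead sits level with both, at a number 5.4 percentage points higher from compound 2 to compound 4 (within the scatter) and a number 1.6 percentage points lower from compound 1 to compound 4 (within the scatter), leaving methyl alone among these four with a clear effect. Nothing measured here explains this drop.

On these data alone, how ethyl or 2-methoxyethyl on this oxygen would read remains open. So does how much change methyl tolerates before the effect disappears.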